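Two enaminone derivatives measured, a third awaiting its number

The compounds below may be only part of what the source reports. "The series", "measured", "known", "first", "only" and "open" are said of these compounds alone.

Measured compounds:
compound 1, `COc1ccc(C(=O)/C=C\Nc2ccc(-c3nc4cc(OC)c(OC)c(OC)c4s3)cc2C)cc1[N+](=O)[O-]`: 13400 nM
compound 2, `COc1ccc(C(=O)/C=C\Nc2ccc(-c3nc4cc(OC)c(OC)c(OC)c4s3)cc2)cc1[N+](=O)[O-]`: 11400 nM

Compound 1 `COc1ccc(C(=O)/C=C\Nc2ccc(-c3nc4cc(OC)c(OC)c(OC)c4s3)cc2C)cc1[N+](=O)[O-]` was tested in a functional assay on HeLa cells (Homo sapiens) for antiproliferative activity, read by sulforhodamine B assay, with a stated time of 48 h (on this read-out lower numbers stand for stronger inhibition and higher numbers for weaker inhibition), and gives 13400 nM. Its nearest neighbour, compound 2 `COc1ccc(C(=O)/C=C\Nc2ccc(-c3nc4cc(OC)c(OC)c(OC)c4s3)cc2)cc1[N+](=O)[O-]`, gives 11400 nM in this assay. For the measured compounds named here, the only measured step, a 1.2-fold lower number from compound 1 to compound 2 (0.07 log units; within the scatter), lies within the scatter, so the two values show no difference to speak of. Compound 1 holds the highest of the two numbers, but only by a margin that means nothing.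

Compound 3 `COc1cc(C(=O)/C=C\Nc2ccc(-c3nc4cc(OC)c(OC)c(OC)c4s3)cc2C)cc(OC)c1OC` differs from compound 1 in another part of the molecule: 3,4,5-trimethoxyphenyl in place of 4-methoxy-3-nitrophenyl on a carbonyl carbon. Going by the values given here, no measured step touches this position; the step from compound 1 to compound 2 concerns the methyl on an aromatic carbon and says nothing about the group on the carbonyl carbon. With no guidance from the measured pairs, the expected step of a 1.5-fold lower number from compound 1 to compound 3 (0.17 log units; within the scatter) is set close to no change beyond the scatter, with a wide range to reflect the absent evidence. Compound 3 is therefore estimated at 9000 nM in this assay, within a range from 1500 nM to 45000 nM.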

Compound 3, half-maximal inhibitory concentration: 11100 nM
Estimate against measurement, compound 3: 1.2-fold (0.09 log units) below; the range from low to high includes it.
By their numbers in this assay, from the lowest: compounds 3, 2 and 1 (each within the scatter of the next).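

In this assay, for the compounds shown here, replacing 4-methoxy-3-nitrophenyl with 3,4,5-trimethoxyphenyl on a carbonyl carbon gives a 1.2-fold lower number from compound 1 to compound 3 (0.08 log units; within the scatter) and is the only measured step at this position, which the step from compound 1 to compound 2 did not touch. It shows that this exchange, in which a group with a nitrogen gives way to one of carbon and oxygen alone and the printed counts of hydrogen-bond donors and acceptors stay the same, leaves the number within the scatter on the core of compound 1. Nothing available here accounts for the two groups reading alike.

The compounds shown leave open whether this holds only for these two substituted phenyl groups, or also for an unsubstituted phenyl, a phenyl carrying an amine or a carboxylic acid, or a saturated ring such as morpholine on the same carbonyl carbon. They also leave open whether 3,4,5-trimethoxyphenyl would read the same with hydrogen in place of the methyl on the aromatic carbon, a pairing that only compound 1 and compound 2 address, and only for 4-methoxy-3-nitrophenyl.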